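Swapping a Ring for a Methoxyethyl Chain on the Core

The source may report more compounds than this note shows. Statements on the series, on what has been measured and on what is new or still open speak of the compounds shown alone.

Three compounds sharing one core differ only in the branched group attached to an aromatic nitrogen. Compound 1 `CCCC(C)n1c(CC)nc2c(-c3ccc(OC)nc3C(F)(F)F)ccnc21` gives 0.6 nM in an assay for binding affinity to Corticotropin releasing factor receptor (Rattus norvegicus); on this read-out lower numbers stand for stronger inhibition and higher numbers for weaker inhibition. Compound 2 `CCc1nc2c(-c3ccc(OC)nc3C(F)(F)F)ccnc2n1C(CC)C1CC1` gives 0.7 nM in this assay, and compound 3 `CCc1nc2c(-c3ccc(OC)nc3C(F)(F)F)ccnc2n1C(C)C1CCC1` gives 0.8 nM. Compound 3 has the highest of the three numbers, but the gaps to the others are small: a 1.3-fold higher number from compound 1 to compound 3 (0.12 log units; within the scatter) and a 1.1-fold higher number from compound 2 to compound 3 (0.06 log units; within the scatter). Likewise a 1.2-fold higher number from compound 1 to compound 2 (0.07 log units; within the scatter). So far, trading one branched hydrocarbon group for another on this nitrogen has left the binding unchanged within the scatter.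

Compound 4 `CCc1nc2c(-c3ccc(OC)nc3C(F)(F)F)ccnc2n1C(CC)CCOC` takes the next step: 1-(2-methoxyethyl)propyl in place of 1-cyclobutylethyl on an aromatic nitrogen. The measured steps all concern groups of carbon only; none of them adds an oxygen to the group on the nitrogen, so they show that exchanging one such group for another has made little difference, but they say nothing about an ether oxygen. The closest guidance is a 1.3-fold higher number from compound 1 to compound 3 (0.12 log units; within the scatter), where a ring replaced a chain without effect. A similarly small step is therefore expected, a 1.5-fold higher number from compound 3 to compound 4 (0.18 log units; within the scatter), with a wider range to allow for the new oxygen. Compound 4 is estimated at 1.2 nM in this assay, within 0.5 nM to 3.5 nM.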

Compound 4, inhibition constant: 1.6 nM
The estimate for compound 4 lay 1.3-fold (0.12 log units) below the measured number; low and high end bracket the measured number.
By their numbers in this assay, from the lowest: compounds 1, 2, 3 and 4 (each within the scatter of the next, the first and the last beyond it).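

Within the data shown here, compound 4 is the first in the set to carry a hydrogen-bond acceptor in the group on this aromatic nitrogen, and it produces the first differences that lie beyond the scatter: a 2.3-fold higher number from compound 2 to compound 4 (0.36 log units; beyond the scatter) and a 2.7-fold higher number from compound 1 to compound 4 (0.43 log units; beyond the scatter), whereas a 2.0-fold higher number from compound 3 to compound 4 (0.30 log units; within the scatter) does not separate the two compounds. The position therefore accepts an open chain containing an ether oxygen, with compound 4 still giving 1.6 nM in this assay, but the change is no longer as neutral as the swaps among carbon-only groups. Nothing available gives a reason for these differences.

Compound 4 brings in the oxygen and a new chain shape together, so these compounds cannot show which of the two matters, and a comparison with an all-carbon chain of similar length, such as a 1-butylpropyl group, would help separate them. As far as these compounds go, it also remains open how binding would respond to an alcohol or an amine in place of the methoxy group, or to a longer chain carrying the same ether.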